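From ethylcarbamoyl to methylsulfonyl in one swap

The compounds below may be only part of what the source reports. "The series", "measured", "known", "first", "only" and "open" are said of these compounds alone.

In an in vivo ADME assay on the whole organism (plasma) for pharmacokinetics, with Rattus norvegicus as the target, at a dose of 5 mg/kg by the intravenous route (on this read-out higher numbers stand for fast clearance and lower numbers for slow clearance), compound 1 `CCNC(=O)c1ccccc1CCC(SCC(CC)C(=O)O)c1cccc(OCc2ccc3ccc(Cl)cc3n2)c1` gives 106 mL/min/kg. For the measured compounds named here, this is the higher of the two numbers measured so far. The other comes from compound 2 `CC(CSC(CCc1ccccc1[N+](=O)[O-])c1cccc(OCc2ccc3ccc(Cl)cc3n2)c1)C(=O)O`, which gives 12 mL/min/kg, and the gap between them lies beyond the usual scatter of repeated measurements. Compound 2 differs from compound 1 in more than one place, so this gap cannot be tied to any single group.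

Compound 3 `CCC(CSC(CCc1ccccc1S(C)(=O)=O)c1cccc(OCc2ccc3ccc(Cl)cc3n2)c1)C(=O)O` has not yet been measured. It shares the core of compound 1 and changes one group: methylsulfonyl in place of ethylcarbamoyl on an aromatic carbon. In words, methylsulfonyl stands in place of ethylcarbamoyl on an aromatic carbon. Going by the values given here, no measured pair shows this swap on its own, so any expectation rests on thin evidence. Among the compounds with values here, the only measured compound without the ethylcarbamoyl group is compound 2, at 12 mL/min/kg, which points towards a lower number. The expected change in this assay is a 3.8-fold lower number from compound 1 to compound 3 (0.58 log units; beyond the scatter), a drop towards slower clearance that would lie beyond the scatter. For compound 3 the estimate is 28 mL/min/kg, with an expected range of 10 mL/min/kg to 75 mL/min/kg.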

Compound 3, clearance: 35 mL/min/kg
Beside the measured number, compound 3's estimate is 1.3-fold (0.10 log units) below it; the range from low to high includes it.
By their numbers in this assay, from the lowest: compound 2; then compound 3; then compound 1.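

Methylsulfonyl in place of ethylcarbamoyl on an aromatic carbon brings a 3.0-fold lower number from compound 1 to compound 3 (0.48 log units; beyond the scatter) in this assay, a step towards slower clearance. The earlier gap could not be tied to any single group, but this step isolates one place: with the rest of compound 1 unchanged, the group on this aromatic carbon, ortho to a large group, is enough on its own to shift clearance beyond the scatter. The swap removes the hydrogen-bond donor of ethylcarbamoyl and brings in a sulfur with two oxygens, and nothing in the data explains why the number falls or which of these differences matters.

Still open, on these data alone, is how other groups on this aromatic carbon would read, for example a nitrile or a simple amine, and whether the trend would hold on a different core. A methylcarbamoyl group, which keeps the amide hydrogen on a shorter chain, and an ethylsulfonyl group, which has a longer chain on the sulfur, could help separate the loss of the amide from the size of the group.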